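Furan-2-yl in place of phenyl: a growth-inhibition step

A few compounds are considered here, and "the series" means these few. Any claim that something is new, unique, unknown or untested is made for them only; others in the source may bear on it.

In a functional assay on DU-145 cells (Homo sapiens), read by sulforhodamine B assay, with a stated time of 5 days (on this read-out lower numbers stand for stronger inhibition of growth and higher numbers for weaker inhibition of growth), compound 1 (`OC[C@H]1O[C@@H](n2cc(F)c3c(-c4ccco4)ncnc32)[C@H](O)[C@@H]1O`) gives 5 nM and compound 2 (`OC[C@H]1O[C@@H](n2cc(Cl)c3c(-c4ccccc4)ncnc32)[C@H](O)[C@@H]1O`) gives 140 nM on the same read-out. Compound 2 therefore holds the higher of the two numbers, and its gap to compound 1 lies beyond the scatter. For the measured compounds named here, no measured pair yet shows the effect of a change in one place alone, so any forecast here rests on thin evidence.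

Compound 3 (`OC[C@H]1O[C@@H](n2cc(Cl)c3c(-c4ccco4)ncnc32)[C@H](O)[C@@H]1O`) departs from compound 2 in one place, with furan-2-yl in place of phenyl on an aromatic carbon of the shared core. Going by the values given here, the only furan-2-yl compound measured so far, compound 1, gives 5 nM and this single value is the ground for expecting a lower number. The expected change in this assay is a 12-fold lower number from compound 2 to compound 3 (1.07 log units; beyond the scatter) toward stronger inhibition of growth, a step estimated to lie beyond the scatter. For compound 3 the estimated value is 12 nM with an expected range from 3 nM to 50 nM in this test.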

Compound 3, concentration for 50% growth inhibition: > 10000 nM
Compound 3 ended at the assay's limit (the forecaster's own chance of this, stated with the estimate: 1%); middle value at least 830-fold (2.92 log units) away from the limit.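

In this assay compound 3 gives > 10000 nM, which is a limit of the assay and not a number: the limit of > 10000 nM in this assay, at which 1 of the 3 values shown sits.

Furan-2-yl in place of phenyl on this aromatic carbon brings an at least 71-fold higher number from compound 2 to compound 3 (1.85 log units; beyond the scatter), so with chloro on the shared core the furan-2-yl group does not go with a lower number, as the single value of compound 1 had suggested. Chloro in place of fluoro on an aromatic carbon brings an at least 2000-fold higher number from compound 1 to compound 3 (3.30 log units; beyond the scatter), a step the earlier compounds could not show because they differ in two places, and with furan-2-yl held fixed this one exchange of halogen separates a low number from the limit of the assay.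

The compounds shown leave open how a fluoro compound carrying phenyl at this position would read, so the phenyl and furan-2-yl groups cannot yet be compared on a fluoro core. They also leave open whether thiophen-2-yl or an amine on this aromatic carbon, or bromo in place of chloro, would stay at the limit or give a measurable number.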